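The source may hold more compounds than are shown below. What is called first, only, known or untested is meant among the compounds shown, and "the series" means these compounds.

Compound 1 `CN(C)CCCNc1c(C(=O)NCc2ccc(F)cc2)nc(Br)c2cccnc12`: > 10000 nM
Compound 2 `O=C(NCCCNc1c(C(=O)NCc2ccc(F)cc2)nc(Br)c2cccnc12)c1ccccc1`: > 10000 nM

In a functional assay on HCT-116 cells (Homo sapiens) for cytotoxicity, read by MTT assay, with a stated time of 72 h (on this read-out lower numbers stand for stronger inhibition and higher numbers for weaker inhibition), compound 1 gives > 10000 nM, which is a limit of the assay rather than a number. Compound 2 likewise gives only a limit, > 10000 nM. Among the compounds with values here, the step that the two limits leave unreadable from compound 1 to compound 2 therefore has no readable size: the one change that has been tried, at the end of a chain, cannot be scored. Where compound 1 stands can be stated only as a limit; no number places it.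

Compound 3 `Cc1ccc(S(=O)(=O)Oc2c(C(=O)NCc3ccc(F)cc3)nc(Br)c3cccnc23)cc1` has not yet been measured. It differs from compound 1 by ((4-methylphenyl)sulfonyl)oxy in place of (3-(dimethylamino)propyl)amino on an aromatic carbon. Within the data shown here, no measured step touches this position or this kind of exchange; the only known step, a step that the two limits leave unreadable from compound 1 to compound 2, was unreadable, and both readings sit at the limit of > 10000 nM in this assay, at which 2 of the 2 values shown sit. Nothing among these two compounds therefore points to a direction or a size for the change to compound 3. The expectation is that compound 3 also lands at or beyond the same limit, so the estimated step is a step that the limit leaves unreadable from compound 1 to compound 3. Compound 3 is accordingly estimated at 20000 nM, within 5000 nM to 80000 nM.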

Compound 3, half-maximal inhibitory concentration: > 20000 nM
Compound 3: a limit, no number; the forecaster's own chance of this, stated with the estimate: 70%; the middle value lies on the limit itself.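

In this assay compound 3 gives > 20000 nM, which is a limit and not a number. Compound 1 also has only a limit, and the step between compound 1 and compound 3 cannot be read. Left open is whether either exchange on the shared core changes the read-out at all, and what number any of the three compounds would have.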